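A few compounds are considered here, and "the series" means these few. Any claim that something is new, unique, unknown or untested is made for them only; others in the source may bear on it.

Measured compounds in a functional assay on HeLa cells (Homo sapiens) for antiproliferative activity, read by MTT assay, with a stated time of 72 h; on this read-out higher numbers stand for weaker inhibition and lower numbers for stronger inhibition:
Compound 1 `O=c1c(Cl)c(CSC(=S)N2CCCCC2)oc2ccccc12` gives 9800 nM.
Compound 2 `CC(C)N(C(=S)SCc1oc2ccccc2c(=O)c1Cl)C(C)C` gives > 40000 nM, which is a limit of the assay and not a number.
Compound 3 `O=c1c(Cl)c(CSC(=S)N2CCCC2)oc2ccccc12` gives 700 nM.

Among these, compound 3 holds the lowest number, and therefore the strongest inhibition; compound 1 stands a clear step above it, and compound 2 is known only as a limit. Two measured steps show how much the amine on the thiocarbonyl carbon matters: a 14-fold lower number from compound 1 to compound 3 (1.15 log units; beyond the scatter), whereas an at least 4.0-fold higher number from compound 1 to compound 2 (0.61 log units; beyond the scatter). Compound 4 `O=c1c(Cl)c(CSC(=S)N2CCOCC2)oc2ccccc12` takes the next step from compound 3: morpholin-4-yl in place of pyrrolidin-1-yl on a thiocarbonyl carbon. The ring that enters has the same count of ring atoms as the piperidin-1-yl of compound 1, with an oxygen added, so the step that bears most directly on it is the one in which a 14-fold lower number from compound 1 to compound 3 (1.15 log units; beyond the scatter), now run in reverse. A rise in this assay is expected, probably large. Compound 4 is expected to give about 9000 nM, with a range from 2000 nM to 40000 nM. The expected step is a 13-fold higher number from compound 3 to compound 4 (1.11 log units; beyond the scatter).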

Compound 4, half-maximal inhibitory concentration: 4500 nM
Beside the measured number, compound 4's estimate is 2.0-fold (0.30 log units) above it; measured number inside the range.
By their numbers in this assay, from the lowest: compound 3; then compound 4; then compound 1. At a limit, above all of these: compound 2.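

Ring size alone does not set the activity on this thiocarbonyl carbon: in this assay there is a 2.2-fold lower number from compound 1 to compound 4 (0.34 log units; beyond the scatter) between two six-membered rings, the morpholin-4-yl and the piperidin-1-yl. Even so, morpholin-4-yl does not match pyrrolidin-1-yl, with a 6.4-fold higher number from compound 3 to compound 4 (0.81 log units; beyond the scatter) in the same read-out, so among the three rings the order from the lowest number is pyrrolidin-1-yl, morpholin-4-yl, piperidin-1-yl. Compound 2 has a limit of the assay and not a number, so an at least 8.8-fold lower number from compound 2 to compound 4 (0.94 log units; beyond the scatter) gives only a minimum size for the step away from diisopropylamino: the limit of > 40000 nM in this assay, at which 1 of the 4 values shown sits.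

The compounds shown leave open whether a four-membered azetidin-1-yl ring would continue this order. They also leave open whether a piperazin-1-yl ring, with a second nitrogen where morpholin-4-yl has its oxygen, would land near compound 4.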